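Adding a cyano group to a compound read only as a limit

The source may report more compounds than this note shows. Statements on the series, on what has been measured and on what is new or still open speak of the compounds shown alone.

In an ADME assay on HFF cells (Homo sapiens) for cytotoxicity (on this read-out higher numbers stand for weaker inhibition and lower numbers for stronger inhibition), compound 1 `N#Cc1cn(COC(CO)CO)c2ncnc(N)c12` gives > 320000 nM as its reading, which is a limit and not a number. Compound 2 `Nc1ncnc2c1ccn2C(CO)OC(CO)CO` gives > 100000 nM as its reading, again a limit. Among the compounds with values here, compound 2 therefore has no exact number, and neither does the only other compound measured. Compound 3 `N#Cc1cn(C(CO)OC(CO)CO)c2ncnc(N)c12` keeps the side chain of compound 2 and differs in one place: cyano in place of hydrogen on an aromatic carbon in words, cyano in place of hydrogen on an aromatic carbon. Within the data shown here, compound 1 also carries a cyano, on a different side chain, and no measured pair shows this change alone. The estimated step that the limit leaves unreadable from compound 2 to compound 3 is expected to stay within the usual scatter in this assay and to lean, if at all, towards weaker inhibition. For compound 3 the expected value is 150000 nM with a range from 50000 nM to 400000 nM and the reading may well be a limit again.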

Compound 3, half-maximal inhibitory concentration: > 100000 nM
Compound 3: a limit, no number; the forecaster's own chance of this, stated with the estimate: 85%; the middle value lies beyond the limit too.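

Within the data shown here, compound 3, like compound 1 and compound 2, gives only a limit in this assay, and no step from compound 1 or compound 2 to compound 3 can be read. The compounds shown leave open whether cyano in place of hydrogen changes cytotoxicity at all, and at what concentration any of them would inhibit these cells.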